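This account rests on a few compounds, and the source may have more. Where it says the series, first, only, none or still open, it means among the compounds named here.

Measured so far in a functional assay on brain (Rattus norvegicus, strain Wistar) for inhibition; on this read-out higher numbers stand for weaker inhibition and lower numbers for stronger inhibition:
- compound 1 `CCCCc1ccc(-c2c(C)[nH]c(=O)n2C)cc1`: 10700 nM
- compound 2 `CCCCOc1ccc(-c2c(C)[nH]c(=O)n2C2CCCCC2)cc1`: 13900 nM

Compound 1 stands level with compound 2, as the two values lie within the scatter of each other, and neither can be ranked. Compound 2 differs from compound 1 in more than one place, so the pair gives no single-change guide.

Compound 3 `CCCCc1ccc(-c2c(C)[nH]c(=O)n2Cc2ccccc2)cc1` has not yet been measured. It departs from compound 1 by one change: phenyl in place of hydrogen on a saturated chain carbon bound to an aromatic nitrogen. This is phenyl in place of hydrogen on a saturated chain carbon bound to an aromatic nitrogen, or methyl to benzyl.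

Among the measured compounds shown here, no measured step covers this change, so the expectation in this assay is weakly founded. The expected step, a 1.3-fold lower number from compound 1 to compound 3 (0.13 log units; within the scatter), is estimated to stay within the scatter, with no firm direction. For compound 3 the expected value is 8000 nM, with an estimated range of 2500 nM to 25000 nM.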

Compound 3, half-maximal inhibitory concentration: 12400 nM
Compound 3: middle estimate off by 1.6-fold (0.19 log units), on the low side, and the stated range covers the measured number.
By their numbers in this assay, from the lowest: compounds 1, 3 and 2 (each within the scatter of the next).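

In this assay, phenyl in place of hydrogen on a saturated chain carbon bound to an aromatic nitrogen, read as methyl to benzyl, gives a 1.2-fold higher number from compound 1 to compound 3 (0.06 log units; within the scatter). Among the compounds shown here, this is the first single-change reading, and it shows that an added aromatic ring at this place leaves compound 3 level with compound 1, so the change neither gains nor loses anything that can be resolved here. No measured evidence on hand bears on this result.

The compounds shown leave open whether any group at this place can move the number beyond the scatter, for instance an amine or a carboxylic acid carried on the benzyl ring, or a longer chain ending in phenyl. They also leave open whether a change elsewhere on the core of compound 1 would do so.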